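Shortening the imine-nitrogen alkyl of compound 1

The compounds below may be only part of what the source reports. "The series", "measured", "known", "first", "only" and "open" are said of these compounds alone.

Within the data shown here, compound 1 `CC(C)C/N=c1\c(O)c(O)\c1=N/Cc1ccc(C#N)cc1` is the weakest inhibitor of the three measured members: in a functional assay for inhibition, with Rattus norvegicus as the target (on this read-out higher numbers stand for weaker inhibition and lower numbers for stronger inhibition), compound 1 gives 10200 nM. Compound 2 `CCC(C)(C)/N=c1\c(O)c(O)\c1=N/Cc1c(C)cc(C)cc1C` gives 310 nM in this assay, and compound 3 `CCC(C)(C)/N=c1\c(O)c(O)\c1=N/Cc1c(Cl)cccc1Cl` gives 280 nM in this assay; both numbers lie well below that of compound 1, beyond the scatter, yet each of these compounds differs from compound 1 in more than one place, so no single change can be read out of them. Compound 4 `CC(C)/N=c1\c(O)c(O)\c1=N/Cc1ccc(C#N)cc1` is not yet measured. It differs from compound 1 by isopropyl in place of isobutyl on a double-bonded nitrogen. Among the measured compounds shown here, no measured pair isolates this change. The expected step of a 1.2-fold higher number from compound 1 to compound 4 (0.07 log units; within the scatter) is small and within the scatter, with no clear direction. Compound 4 is therefore expected to give 12000 nM in this assay, with a range from 4000 nM to 40000 nM.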

Compound 4, half-maximal inhibitory concentration: 14000 nM
Compound 4: the middle estimate sits 1.2-fold (0.07 log units) below what was measured; low and high end bracket the measured number.
By their numbers in this assay, from the lowest: compounds 3 and 2 (each within the scatter of the next); then compounds 1 and 4 (each within the scatter of the next).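

Isopropyl in place of isobutyl on a double-bonded nitrogen gives the first single-change comparison in the series in this assay, with a 1.4-fold higher number from compound 1 to compound 4 (0.14 log units; within the scatter). With the rest of the structure held fixed, this position tolerates the swap from the 4-carbon to the 3-carbon group without a change beyond the scatter. No available evidence bears on this result.

As far as these compounds go, whether a longer chain such as n-hexyl, or a cyclohexyl ring, at this position would move the number beyond the scatter remains open. From the compounds shown here alone, how the lower numbers of compounds 2 and 3 divide among their several differences from compound 1 also remains open.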